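Phenyl in place of hydroxypentyl on the aromatic nitrogen

The compounds below may be only part of what the source reports. "The series", "measured", "known", "first", "only" and "open" are said of these compounds alone.

Of the compounds shown here, two sharing one core have been tested in a functional assay on HT-29 cells (Homo sapiens) for cytotoxicity, read by MTT assay, with a stated time of 72 h; on this read-out lower numbers stand for stronger inhibition of growth and higher numbers for weaker inhibition of growth. Compound 1 `CSc1nc(NCc2ccccc2)c2ccccc2n1` carries a benzyl group on a nitrogen attached to the aromatic core. In this assay compound 1 gives only a limit of the assay, > 100000 nM. Compound 2 `CSc1nc(NCCCCCO)c2ccccc2n1` carries a 5-hydroxypentyl chain on that nitrogen in place of the benzyl group. In this assay compound 2 likewise gives only a limit, > 100000 nM. Compound 2 thus stands at the limit of > 100000 nM in this assay, at which 2 of the 2 values shown sit, and nothing more precise about its potency is known. The step that the two limits leave unreadable from compound 1 to compound 2 cannot be read, because both ends are limits.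

Compound 3 `CSc1nc(Nc2ccccc2)c2ccccc2n1` differs from compound 2 by phenyl in place of 5-hydroxypentyl on a nitrogen on an aromatic ring. Within the data shown here, the single measured step, from compound 1 to compound 2, is unreadable and offers no direction for this change. Compound 1, which also carries a phenyl ring though on a chain carbon, sits at the limit. Compound 3 is therefore expected to give about 100000 nM in this assay, between 30000 nM and 300000 nM, most likely again only as a limit. The estimated step of a number no higher from compound 2 to compound 3 (the limit leaves the size open) is expected to be none beyond the scatter.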

Compound 3, concentration for total growth inhibition: > 100000 nM
Compound 3 ended at the assay's limit (the forecaster's own chance of this, stated with the estimate: 80%); the middle value sits exactly at the limit.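

Compound 2 and compound 3 both give only a limit of the assay, so the step between them cannot be read, and compound 3 stands with the others: the limit of > 100000 nM in this assay, at which 3 of the 3 values shown sit.

The compounds shown leave open how far the growth-inhibiting concentration of any of them lies past that limit, and which group on the nitrogen would give a measurable value in this assay.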